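Cutting benzyloxycarbonyl back to methoxycarbonyl

The source may report more compounds than this note shows. Statements on the series, on what has been measured and on what is new or still open speak of the compounds shown alone.

In an ADME assay on a cell-free system (plasma, Homo sapiens), read by HPLC, with a stated time of 120 min, at 37 degrees C (on this read-out higher numbers stand for a more stable compound and lower numbers for a less stable compound), compound 3 (`C[C@@H]1CN(C(=O)c2nc(Nc3cc(C4CC4)[nH]n3)c3cc(Cl)ccc3n2)CCN1C(=O)OCc1ccccc1`) stands highest of three at 86.2% against compound 1 (`CC(C)COC(=O)N1CCN(C(=O)c2nc(Nc3cc(C4CC4)[nH]n3)c3cc(Cl)ccc3n2)C[C@H]1C`) with 73.7% and compound 2 (`CC(C)C(=O)OCOC(=O)N1CCN(C(=O)c2nc(Nc3cc(C4CC4)[nH]n3)c3cc(Cl)ccc3n2)C[C@H]1C`) with 6.1% on the same read-out. Compound 4 (`COC(=O)N1CCN(C(=O)c2nc(Nc3cc(C4CC4)[nH]n3)c3cc(Cl)ccc3n2)C[C@H]1C`) carries hydrogen in place of phenyl on a saturated chain carbon bound to an oxygen next to a carbonyl group. The nearest guide is the modest step of a number 12.5 percentage points higher from compound 1 to compound 3 (beyond the scatter) when phenyl replaces isopropyl at that place. The large steps of a number 67.6 percentage points lower from compound 1 to compound 2 (beyond the scatter) and a number 80.1 percentage points higher from compound 2 to compound 3 (beyond the scatter) involve (isopropylcarbonyl)oxy, absent from compound 4, and say little here. A fall no larger than the scatter is therefore expected (a number 8.2 percentage points lower from compound 3 to compound 4 (within the scatter)). Compound 4 is estimated at 78% (range 62% to 92%).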

Compound 4, percent of the compound remaining: 84.6%
Compound 4: middle estimate off by 6.6 percentage points, on the low side; low and high end bracket the measured number.
By their numbers in this assay, from the lowest: compound 2; then compound 1; then compounds 4 and 3 (each within the scatter of the next).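

In this assay, taking the phenyl away from the saturated chain carbon leaves the number within the scatter (a number 1.6 percentage points lower from compound 3 to compound 4 (within the scatter)), so methoxycarbonyl and benzyloxycarbonyl cannot be told apart here. Isopropyl on that carbon, by contrast, stands modestly apart from hydrogen (a number 10.9 percentage points higher from compound 1 to compound 4 (beyond the scatter)), and (isopropylcarbonyl)oxy stands far apart (a number 78.5 percentage points higher from compound 2 to compound 4 (beyond the scatter)). Nothing measured here accounts for these differences. On these data alone, whether an amine or a carboxylic acid on that same carbon would stay with hydrogen and phenyl or fall towards (isopropylcarbonyl)oxy remains open.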